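A few compounds are considered here, and "the series" means these few. Any claim that something is new, unique, unknown or untested is made for them only; others in the source may bear on it.

Three compounds have numbers in a functional assay on MIA PaCa-2 cells (Homo sapiens) for inhibition, read by MTT assay, with a stated time of 3 days; on this read-out lower numbers stand for stronger inhibition and higher numbers for weaker inhibition. Compound 1 `CCOC(=O)[C@@H]1CCCN(S(=O)(=O)c2ccc(S(=O)(=O)N(CC)CC)c(F)c2)C1` gives 200 nM. Compound 2 `CCOC(=O)[C@@H]1CCCN(S(=O)(=O)c2ccc(S(=O)(=O)N3CCCCC3)cc2)C1` gives 1000 nM. Compound 3 `CC(C)c1noc(N2CCN(C(=O)[C@@H]3CCCN(S(=O)(=O)c4ccc(S(=O)(=O)C5CCC5)cc4)C3)CC2)n1` gives 20 nM, the lowest of the three numbers; its gaps to compound 1 and to compound 2 both lie beyond the scatter. For the measured compounds named here, compounds 1 and 2 differ from compound 3 in more than one place, so no single step among the measured compounds isolates any one change. Compound 4 `CC(C)c1noc(N2CCN(C(=O)[C@@H]3CCCN(S(=O)(=O)c4ccc(S(=O)(=O)NC5CC5)cc4)C3)CC2)n1` differs from compound 3 in one place only: cyclopropylamino in place of cyclobutyl on a sulfonyl sulfur. Going by the values given here, no measured pair shows this change, so the expectation rests on the size of the exchange alone. The expected step is a 1.5-fold higher number from compound 3 to compound 4 (0.18 log units; within the scatter), not beyond the scatter. Compound 4 is therefore estimated at 30 nM, within a range from 10 nM to 100 nM in this assay.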

Compound 4, half-maximal inhibitory concentration: 300 nM
Compound 4: middle estimate off by 10-fold (1.00 log units), on the low side; measured number above the stated range.
By their numbers in this assay, from the lowest: compound 3; then compounds 1 and 4 (each within the scatter of the next); then compound 2.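

On a sulfonyl sulfur whose other neighbour is an aromatic carbon, the exchange of cyclobutyl for cyclopropylamino is not a neutral swap: in this assay it gives a 15-fold higher number from compound 3 to compound 4 (1.18 log units; beyond the scatter). For the compounds shown here, this is the first single-place step, and the heavy-atom count does not change across it, so that count does not predict the step. The entering group differs in its ring size and its hydrogen-bond donor.

Cyclopropyl or cyclobutylamino on the same sulfur would separate these two differences. No measurement shown gives a reason for the step.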